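Moving the Chlorine Around the Aromatic Ring

The source may report more compounds than this note shows. Statements on the series, on what has been measured and on what is new or still open speak of the compounds shown alone.

Of the compounds shown here, three built on one shared core have been measured so far. Compound 1 `O=C1CSC(c2cccc(O)c2)N1CCN1CCCCC1` carries a 3-hydroxyphenyl group, compound 2 `O=C1CSC(c2cccc(F)c2)N1CCN1CCCCC1` a 3-fluorophenyl group, and compound 3 `O=C1CSC(c2ccccc2Cl)N1CCN1CCCCC1` a 2-chlorophenyl group, each on the same saturated ring carbon of the core. In an ADME assay on Vero cells (Chlorocebus sabaeus) for cytotoxicity, read by neutral red uptake, tested at 12.3 ug/mL (a higher number here means a weaker effect of the compound at the concentration tested, a lower number a stronger effect), compound 1 gives 100%. In this assay compound 2 gives 100%, and compound 3 gives 100%.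

Exchanging one aromatic group for another left the read-out untouched: no change at the digits printed from compound 1 to compound 2 (within the scatter), no change at the digits printed from compound 1 to compound 3 (within the scatter), and no change at the digits printed from compound 2 to compound 3 (within the scatter). Compound 3 therefore stands level with compound 1 and compound 2, all three at the top of the scale, which means no measurable effect on the cells at the concentration tested.

Compound 4 `O=C1CSC(c2ccc(Cl)cc2)N1CCN1CCCCC1` has not yet been measured. It differs from compound 3 in a single place: 4-chlorophenyl in place of 2-chlorophenyl on a saturated ring carbon. The measured steps that bear on this change are the two that also swapped the aromatic group on that carbon, no change at the digits printed from compound 1 to compound 3 (within the scatter) and no change at the digits printed from compound 2 to compound 3 (within the scatter), and both lay within the scatter. For compound 4 a step in this assay of no more than the scatter is therefore expected, no change at the digits printed from compound 3 to compound 4 (within the scatter). Compound 4 is estimated to give 100%, with a range from 88% to 100%.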

Compound 4, a percentage reported as activity, at one concentration (the size of the read-out at that concentration, not a potency): 90%
The estimate for compound 4 lay 10 percentage points above the measured number, within the range that was stated.
By their numbers in this assay, from the lowest: compounds 4, 1, 2 and 3 (each within the scatter of the next).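

In this assay, going by these compounds alone, exchanging 2-chlorophenyl for 4-chlorophenyl on the saturated ring carbon gives the first step at this position that is not zero at the digits printed (a number 10 percentage points lower from compound 3 to compound 4 (within the scatter)), and the steps from the other two compounds read the same way (a number 10 percentage points lower from compound 2 to compound 4 (within the scatter); a number 10 percentage points lower from compound 1 to compound 4 (within the scatter)). All three steps stay within the usual scatter, so the four aromatic groups on this carbon cannot be told apart here, and the chlorine gives no distinguishable read-out as either 2-chlorophenyl or 4-chlorophenyl. Nothing available offers an explanation for the number seen with compound 4.

The compounds shown carry only a hydroxy, fluoro or chloro group on the aromatic ring, so it remains open whether an amine or a carboxylic acid there, or a longer chain in place of the aromatic group, would stay within the scatter in the same way. Each compound also has a read-out at only one concentration, so these numbers cannot say how the compounds would behave on the cells at higher concentrations.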